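The compounds below may be only part of what the source reports. "The series", "measured", "known", "first", "only" and "open" are said of these compounds alone.

Among the compounds with values here, compound 2 `CCC(NC(=O)C(CC(C)C)NC(=O)OCc1ccccc1)C(=O)C(=O)NCC(C)C` is the stronger of the two compounds measured so far: in an assay on isolated protein (Oryctolagus cuniculus) for inhibition of Calpain-2 catalytic subunit (Homo sapiens), at pH 8.0 (on this read-out higher numbers stand for weaker inhibition and lower numbers for stronger inhibition), compound 2 gives 140 nM, while compound 1 `CCCCOC(=O)C(=O)C(CC)NC(=O)C(CC(C)C)NC(=O)OCc1ccccc1` gives 400 nM. Within the data shown here, the single measured step, a 2.9-fold lower number from compound 1 to compound 2 (0.46 log units; beyond the scatter), came from swapping the group on the carbonyl carbon at the amide end of the shared core. Compound 3 `CCC(NC(=O)C(CC(C)C)NC(=O)OCc1ccccc1)C(=O)C(=O)NCC1CCCCC1` changes that same end again, this time as cyclohexyl in place of isopropyl on a saturated chain carbon bound to an amide-type nitrogen. Among the measured compounds shown here, that earlier step touches the same region but is a different kind of change, so it offers only loose guidance; no measured pair compares isopropyl with cyclohexyl directly. A small gain at best, or no change beyond the scatter, is therefore expected, written as a 1.4-fold lower number from compound 2 to compound 3 (0.15 log units; within the scatter). Compound 3 is estimated to give 100 nM in this assay, with a plausible range from 30 nM to 350 nM.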

Compound 3, inhibition constant: 44 nM
Estimate against measurement, compound 3: 2.3-fold (0.36 log units) above; the measured number falls inside the stated range.
By their numbers in this assay, from the lowest: compound 3; then compound 2; then compound 1.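

The isopropyl end of compound 2 is not the limit at this position: with cyclohexyl in place of isopropyl on a saturated chain carbon bound to an amide-type nitrogen, this assay shows a 3.2-fold lower number from compound 2 to compound 3 (0.50 log units; beyond the scatter). Measured against the ester, (cyclohexylmethyl)amino in place of butoxy on a carbonyl carbon gives a 9.1-fold lower number from compound 1 to compound 3 (0.96 log units; beyond the scatter), the largest step among these compounds. Nothing available explains why the number falls with this change.

These compounds cannot tell whether the ring itself matters or simply the extra carbons, a question that an open chain such as n-hexyl could help settle. Also open, as far as these compounds go, is how a flat phenyl ring, a longer 2-cyclohexylethyl group or a ring carrying an amine, such as piperidine, would compare at this position.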